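This account rests on a few compounds, and the source may have more. Where it says the series, first, only, none or still open, it means among the compounds named here.

Going by the values given here, compound 2 `O=C(Nc1ccc(NC2CCCCC2)cc1Cl)c1cc(Cl)ccc1O` stands highest of the two numbers so far in an ADME assay on A549 cells (Homo sapiens) for cytotoxicity, read by resazurin assay, with a stated time of 48 h (a lower number here means that less compound is tolerated, a higher number that more compound is tolerated), where compound 2 gives 68300 nM. Its nearest neighbour is compound 1 `O=C(Nc1ccc(NCC2CCCC2)cc1Cl)c1cc(Cl)ccc1O`, which in this assay gives 21500 nM; the step of a 3.2-fold higher number from compound 1 to compound 2 (0.50 log units; beyond the scatter). Compound 3 `O=C(Nc1ccc(NCc2cc(Cl)cc(Cl)c2)cc1Cl)c1cc(Cl)ccc1O` has not yet been measured. It differs from compound 2 in one place: 3,5-dichlorobenzyl in place of cyclohexyl on a nitrogen on an aromatic ring. Among the compounds with values here, no measured step exchanges a cyclohexyl for a 3,5-dichlorobenzyl, so the single known step bears on it only loosely, showing that the group on this nitrogen moves the number by a modest amount. A step of similar or somewhat larger size is therefore expected, most likely downward, because a 3.2-fold higher number from compound 1 to compound 2 (0.50 log units; beyond the scatter) raised the number when cyclohexyl replaced cyclopentylmethyl and the new change takes the cyclohexyl away again. The expected step is a 3.4-fold lower number from compound 2 to compound 3 (0.53 log units; beyond the scatter). Compound 3 is thus estimated at 20000 nM, with a range from 6000 nM to 60000 nM.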

Compound 3, half-maximal cytotoxic concentration: 13300 nM
For compound 3 the middle estimate is 1.5-fold (0.18 log units) above the measured one, and the stated range covers the measured number.
By their numbers in this assay, from the lowest: compounds 3 and 1 (each within the scatter of the next); then compound 2.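

In this assay, exchanging the saturated ring on this nitrogen for an aromatic one gives a 5.1-fold lower number from compound 2 to compound 3 (0.71 log units; beyond the scatter) and so the cyclohexyl of compound 2 now stands apart from both other groups, beyond the scatter. The replacement of cyclopentyl by 3,5-dichlorophenyl on the saturated chain carbon gives a 1.6-fold lower number from compound 1 to compound 3 (0.21 log units; within the scatter) and so these two groups cannot be told apart here, despite the different rings and the two chlorines. Among these three compounds, the two with a saturated chain carbon on the nitrogen therefore lie together, while compound 2, with its ring bound directly to the nitrogen, lies higher, and nothing available explains this difference.

From the compounds shown here alone, it remains open whether the higher number follows from that direct attachment or from cyclohexyl itself. A cyclohexylmethyl group or a phenyl group on this nitrogen would separate the two readings.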